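Amide Carbonyl Substituent Swap: Expected Inhibition of Compound 3

A few compounds are considered here, and "the series" means these few. Any claim that something is new, unique, unknown or untested is made for them only; others in the source may bear on it.

Measured so far:
compound 1 `Cc1cccc(Cn2c(CN3CCN(C(=O)C4CCCCC4)CC3)nc3ccccc32)c1`: 31.9%
compound 2 `Cc1cccc(Cn2c(CN3CCN(C(=O)c4ccc(F)cc4)CC3)nc3ccccc32)c1`: 27.1%

For the measured compounds named here, in an assay on isolated protein for inhibition of aldehyde dehydrogenase 1A1 (Homo sapiens), read by spectrophotometry, tested at 10 uM (on this read-out higher numbers stand for more inhibition at the one concentration tested (going by the name of the read-out) and lower numbers for less inhibition), compound 2 gives 27.1%, and its only neighbour is compound 1, the gap being within the scatter: a number 4.8 percentage points lower from compound 1 to compound 2 (within the scatter). Compound 3 `CCCC(=O)N1CCN(Cc2nc3ccccc3n2Cc2cccc(C)c2)CC1` differs from compound 2 by propyl in place of 4-fluorophenyl on a carbonyl carbon. Going by the values given here, the single measured step, also on the carbonyl carbon, stayed within the scatter, and no measured step covers propyl, so no step beyond the scatter is expected for compound 3. Its inhibition is estimated at 25%, between 10% and 40%. The expected step is a number 2.1 percentage points lower from compound 2 to compound 3 (within the scatter).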

Compound 3, a percentage reported as inhibition, at one concentration (the size of the read-out at that concentration, not a potency): 79.1%
Beside the measured number, compound 3's estimate is 54.1 percentage points below it; the whole stated range lies below it.
By their numbers in this assay, from the lowest: compounds 2 and 1 (each within the scatter of the next); then compound 3.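

In this assay, this carbonyl carbon turns out to be far from indifferent to its substituent: propyl in place of 4-fluorophenyl gives a number 52 percentage points higher from compound 2 to compound 3 (beyond the scatter), and propyl in place of cyclohexyl gives a number 47.2 percentage points higher from compound 1 to compound 3 (beyond the scatter). The two ring-bearing substituents had stayed within the scatter of each other, so only the open chain separates from them, and no compound shown goes against that split. Nothing available explains the difference. The compounds shown leave open whether the gain depends on chain length, as ethyl or butyl would show, and whether a small ring such as cyclopropyl or a branched group such as isopropyl would keep it.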